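A few compounds are considered here, and "the series" means these few. Any claim that something is new, unique, unknown or untested is made for them only; others in the source may bear on it.

Working notes on the series, read in a functional assay on HCT-116 cells (Homo sapiens) for inhibition, read by MTT assay, with a stated time of 48 h; on this read-out lower numbers stand for stronger inhibition and higher numbers for weaker inhibition. Within the data shown here, compound 1 (`COc1ccc(CNc2cc(OC)c(OC)c(OC)c2)cc1Br`) gives 48100 nM, the highest of the three numbers so far. Compound 2 (`C/C=C/C(=O)N(Cc1ccc(OC)c(Br)c1)c1cc(OC)c(OC)c(OC)c1`) stands at 2800 nM and compound 3 (`COc1ccc(CN(C(=O)CN=[N+]=[N-])c2cc(OC)c(OC)c(OC)c2)cc1O`) at 410 nM.

Among the measured compounds shown here, compound 4 (`COc1ccc(CNc2cc(OC)c(OC)c(OC)c2)cc1C`) has no measurement yet. It departs from compound 1 by a single change, methyl in place of bromo on an aromatic carbon, ortho to a methoxy group: methyl in place of bromo on an aromatic carbon.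

For the measured compounds named here, the only measured step between compounds that differ in one place is a 17-fold lower number from compound 1 to compound 2 (1.23 log units; beyond the scatter). It is large, but it concerns (prop-1-en-1-yl)carbonyl in place of hydrogen on a nitrogen on an aromatic ring, and the bromo stays in place. Compound 1 and compound 3 differ in more than one place, so the value of compound 3, 410 nM, cannot be tied to any single change. Going by the values given here, no measured step replaces the bromo alone, and the data give no direction for this swap.

No step beyond the scatter is therefore expected in this assay, and the expected step is a 1.1-fold lower number from compound 1 to compound 4 (0.03 log units; within the scatter). For compound 4 the estimated value is 45000 nM, with an expected range of 18000 nM to 100000 nM.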

Compound 4, half-maximal inhibitory concentration: 60900 nM
The estimate for compound 4 lay 1.4-fold (0.13 log units) below the measured number; low and high end bracket the measured number.
By their numbers in this assay, from the lowest: compound 3; then compound 2; then compounds 1 and 4 (each within the scatter of the next).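

In this assay, among these compounds, methyl in place of bromo on an aromatic carbon, ortho to a methoxy group, gives a 1.3-fold higher number from compound 1 to compound 4 (0.10 log units; within the scatter) and is the first measured step that changes this position alone. With the rest of the core of compound 1 unchanged, this swap of one heavy atom for one heavy atom produces no step beyond the scatter, so compound 1 and compound 4 stand at one level in this assay. Nothing shown explains why these two substituents read alike.

From the compounds shown here alone, it remains open whether the same swap would read alike with a (prop-1-en-1-yl)carbonyl on the nitrogen, as in compound 2, where the bromo is still present. Also open, going by these compounds, is whether an amine, a carboxylic acid or a longer chain such as propyl on this aromatic carbon would stay within the scatter of the bromo of compound 1 or move the number beyond it.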